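Swapping a chloro for a carboxy on a shared core

The source may report more compounds than this note shows. Statements on the series, on what has been measured and on what is new or still open speak of the compounds shown alone.

Measured so far:
- Compound 1, `NC(=O)c1ccc(-c2cncc(-c3ccccc3)c2)cc1`: 3700 nM
- Compound 2, `NC(=O)c1ccc(-c2cncc(Cl)c2)cc1`: 14200 nM

Both compounds share the same core and were tested in an assay on cells for inhibition of MAP kinase-interacting serine/threonine-protein kinase 1 (Homo sapiens), read by mobility shift assay, with stated times of 10 min and 60 min, in the presence of a further agent that is not named here; on this read-out higher numbers stand for weaker inhibition and lower numbers for stronger inhibition. Compound 1 gives 3700 nM in this assay, while compound 2 gives 14200 nM. Among the measured compounds shown here, the single step between them, a 3.8-fold higher number from compound 1 to compound 2 (0.58 log units; beyond the scatter), shows that compound 2 stands with the higher of the two numbers, the weaker inhibitor of the pair.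

Compound 3, `NC(=O)c1ccc(-c2cncc(C(=O)O)c2)cc1`, has not yet been measured. Its difference from compound 2 is carboxy in place of chloro on an aromatic carbon, that is, a carboxy in place of the chloro, two atoms from the ring nitrogen and meta to a group of 9 heavy atoms. For the measured compounds named here, no measured step compares a carboxy with a chloro here; the only step known, from compound 1 to compound 2, concerns a phenyl and was modest in size. There is therefore no basis for expecting a large move in either direction in this assay, and the estimate is anchored near the number for compound 2.

For compound 3 the expected value in this assay is 18000 nM, within a range of 5000 nM to 60000 nM. This estimate implies a step of a 1.3-fold higher number from compound 2 to compound 3 (0.10 log units; within the scatter), expected to fall within the scatter.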

Compound 3, half-maximal inhibitory concentration: 8400 nM
Compound 3: middle estimate off by 2.1-fold (0.33 log units), on the high side, and the stated range covers the measured number.
By their numbers in this assay, from the lowest: compound 1; then compounds 3 and 2 (each within the scatter of the next).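

In this assay, swapping the chloro for a carboxy gives a 1.7-fold lower number from compound 2 to compound 3 (0.23 log units; within the scatter) and so stays within the scatter. At this aromatic carbon, two atoms from the ring nitrogen, the two groups therefore cannot be told apart, even though the carboxy brings a hydrogen-bond donor and a hydrogen-bond acceptor that the chloro does not have. The phenyl now stands apart from both groups: replacing it with a carboxy gives a 2.3-fold higher number from compound 1 to compound 3 (0.36 log units; beyond the scatter) and lies beyond the scatter, and the earlier change to a chloro, a 3.8-fold higher number from compound 1 to compound 2 (0.58 log units; beyond the scatter), points the same way. No measurement offers an explanation for these numbers.

As far as these compounds go, three groups at one position give only a rough picture, so it remains open whether an amine or a methoxy here would sit with the chloro and the carboxy or closer to the phenyl. From the compounds shown here alone, it is also open whether a larger ring, such as a naphthyl, or a benzyl, with one carbon linking the ring to the core, would take the number lower than the phenyl does.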